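The compounds below may be only part of what the source reports. "The series", "measured", "known", "first", "only" and "open" are said of these compounds alone.

Measured so far:
compound 1 `CCCCCCCCCCc1ccc(-c2noc([C@@H]3CCNC3)n2)cc1` with 62%
compound 2 `CCCCCCCCCCc1ccc(-c2noc(C3CCNCC3)n2)cc1` with 66%

Both were read in an assay on HeLa cells for inhibition of sphingosine-1-phosphate transporter SPNS2 (Mus musculus), read by LC-MS, tested at 2 uM; a higher number here means more inhibition at the concentration tested (going by the name of the read-out), a lower number less inhibition. Compound 2 gives 66% there, the higher of the two numbers, but the step of a number 4 percentage points higher from compound 1 to compound 2 (within the scatter) is within the scatter, so compound 1 and compound 2 are not distinguished by these data.

Compound 3 `CCCCCCCCCCc1ccc(-c2noc(CN3CCNCC3)n2)cc1` is not yet measured. It differs from compound 2 by (piperazin-1-yl)methyl in place of piperidin-4-yl on an aromatic carbon. For the measured compounds named here, the one measured step, piperidin-4-yl in place of pyrrolidin-3-yl, bears on it only loosely: it shows that exchanging one saturated amine ring for another on this aromatic carbon gave a number 4 percentage points higher from compound 1 to compound 2 (within the scatter). Going by the values given here, no step with a methylene link or a second ring nitrogen is available, so the expectation carries wide uncertainty.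

For compound 3 the expectation is 55% with a range of 30% to 78%, that is an estimated step of a number 11 percentage points lower from compound 2 to compound 3 (beyond the scatter), which may stay within the scatter.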

Compound 3, a percentage reported as inhibition, at one concentration (the size of the read-out at that concentration, not a potency): 19%
Compound 3: middle estimate off by 36 percentage points, on the high side; measured number outside the range, below it.
By their numbers in this assay, from the lowest: compound 3; then compounds 1 and 2 (each within the scatter of the next).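

At this position on an aromatic carbon, the group matters in this assay: swapping one directly attached saturated amine ring for another left compound 1 and compound 2 undistinguished, whereas a number 47 percentage points lower from compound 2 to compound 3 (beyond the scatter) and a number 43 percentage points lower from compound 1 to compound 3 (beyond the scatter) come with (piperazin-1-yl)methyl in this place. The equivalence of pyrrolidin-3-yl and piperidin-4-yl therefore does not extend to this group, which brings a methylene link and a second ring nitrogen together. Nothing at hand explains the drop.

The compounds shown cannot say whether the methylene link, the second ring nitrogen or the two together go with the lower number, since both change in the same step. Piperazin-1-yl attached directly to the ring and (piperidin-4-yl)methyl would each separate these two changes.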